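From an Amino Group to a Longer Chain on the Core

A few compounds are considered here, and "the series" means these few. Any claim that something is new, unique, unknown or untested is made for them only; others in the source may bear on it.

Two compounds share one fused core and differ only in the group on one aromatic nitrogen. Compound 1 `Cn1c2ccccc2[n+]2nc3c(cc12)-c1cccc2cccc-3c12` carries a methyl there; in a functional assay on HT-29 cells (Homo sapiens) for inhibition, with a stated time of 72 h (a lower number here means that less compound is needed, a higher number that more compound is needed for the effect), compound 1 gives 3700 nM. Compound 2 `Nn1c2ccccc2[n+]2nc3c(cc12)-c1cccc2cccc-3c12` carries an amino group instead, and in this assay compound 2 gives 37000 nM, the higher of the two numbers measured. For the measured compounds named here, the single step between them, a 10-fold higher number from compound 1 to compound 2 (1.00 log units; beyond the scatter), is the only measured change that bears on what follows.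

Compound 3 `NCCNC(=O)Cn1c2ccccc2[n+]2nc3c(cc12)-c1cccc2cccc-3c12` is not yet measured. Relative to compound 2 it has ((2-aminoethyl)carbamoyl)methyl in place of amino on an aromatic nitrogen. Like the methyl of compound 1, the entering group is joined through carbon, so the amino that went with the higher number in compound 2 is gone. Going by the values given here, because a 10-fold higher number from compound 1 to compound 2 (1.00 log units; beyond the scatter) was modest, a downward step of similar size seems the most likely outcome, though the chain is far larger than a methyl and no measured compound shows what such a chain does here. Compound 3 is therefore expected to give 6000 nM in this assay, within a range from 1500 nM to 25000 nM. That estimate means an expected step of a 6.2-fold lower number from compound 2 to compound 3 (0.79 log units; beyond the scatter).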

Compound 3, half-maximal effective concentration: > 100000 nM
Compound 3 ended at the assay's limit; the forecaster's own chance of this, stated with the estimate: 10%; at least 16-fold (1.22 log units) between middle value and limit.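

Compound 3 gives > 100000 nM, which is a limit of this assay and not a number: the limit of > 100000 nM in this assay, at which 1 of the 3 values shown sits. Replacing amino with ((2-aminoethyl)carbamoyl)methyl on the aromatic nitrogen gives an at least 2.7-fold higher number from compound 2 to compound 3 (0.43 log units; beyond the scatter), so joining a group through carbon at this nitrogen does not by itself go with a lower number. Extending the methyl with (2-aminoethyl)carbamoyl gives an at least 27-fold higher number from compound 1 to compound 3 (1.43 log units; beyond the scatter), the largest step among these three compounds, which shows that a change on this chain can move the number much further than the swap of methyl for amino did, and that methyl remains the group with the lowest number here.

The compounds shown leave open which part of the longer chain goes with the higher number, the amide or the amino group it carries. A plain ethyl or propyl chain on the same nitrogen, or the same amide chain ending in a hydroxyl group or a carboxylic acid instead of the amine, would help to separate the effect of chain length from that of the groups along it.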